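Adding the diethylamino side chain to compound 3

A few compounds are considered here, and "the series" means these few. Any claim that something is new, unique, unknown or untested is made for them only; others in the source may bear on it.

Compound 3 (`C=CC(=O)NC/C=C/c1cc(OC)cc(O)c1C(=O)O[C@@H](C)C(C)C`) gives > 10000 nM in a functional assay on MV4-11 cells (Homo sapiens) for antiproliferative activity, read by luminescence, with a stated time of 72 h (a higher number here means a weaker inhibitor, a lower number a stronger inhibitor), as a limit and not a number. Compound 2 (`C=CC(=O)NC/C=C/c1cc(OC)cc(O)c1C(=O)OC(C)C`) gives > 10000 nM in this assay as a limit as well. Compound 1 (`CCN(CC)C/C=C/C(=O)NC/C=C/c1cc(OC)cc(O)c1C(=O)OC(C)C`) gives > 10000 nM in this assay as a limit too. Among the measured compounds shown here, compound 3 therefore has no numerical place, and the only shared reading is (the limit of > 10000 nM in this assay, at which 3 of the 3 values shown sit) with no ranking to be drawn from it.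

Compound 4 (`CCN(CC)C/C=C/C(=O)NC/C=C/c1cc(OC)cc(O)c1C(=O)O[C@@H](C)C(C)C`) carries 3-(diethylamino)prop-1-en-1-yl in place of vinyl on a carbonyl carbon and is otherwise unchanged from compound 3. For the measured compounds named here, two measured steps bear on this change. The same exchange in reverse, on the isopropyl ester, is (a step that the two limits leave unreadable from compound 1 to compound 2) and has no readable size. The change of ester group (a step that the two limits leave unreadable from compound 2 to compound 3) cannot be sized either. Neither step supplies a size or direction to carry over.

Compound 1 holds the same side chain and shows > 10000 nM as a limit, which is the basis for expecting no gain. The estimated step (a number no higher from compound 3 to compound 4 (the limit leaves the size open)) is expected to have no clear direction. For compound 4 the estimated value is 10000 nM within an expected range of 4000 nM to 30000 nM and a limit is the likeliest report.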

Compound 4, half-maximal inhibitory concentration: > 10000 nM
Compound 4: only a limit was reported (the forecaster's own chance of this, stated with the estimate: 85%); the middle value lies on the limit itself.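

No new step can be read: compound 4, like compound 3 and compound 1, is reported only as a limit, so the steps to compound 4 have no size. The series has one shared reading: the limit of > 10000 nM in this assay, at which 4 of the 4 values shown sit.

The compounds shown leave open whether any side chain or ester group here gives a numerical value in this assay.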